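The compounds below may be only part of what the source reports. "The series", "measured", "known", "first", "only" and "open" are said of these compounds alone.

Compound 1 `C/C=C1/[C@H](O[C@@H]2O[C@H](CO)[C@@H](O)[C@H](O)[C@H]2O)OC=C(C(=O)OC)[C@H]1CC(=O)NCCC` carries a propylamino group on a carbonyl carbon of the shared core. In a functional assay on SK-BR-3 cells (Homo sapiens) for antiproliferative activity, read by MTT assay, with a stated time of 72 h (on this read-out higher numbers stand for weaker inhibition and lower numbers for stronger inhibition), compound 1 gives only a limit of the assay, > 20000 nM, and no number. Compound 2 `C/C=C1/[C@H](O[C@@H]2O[C@H](COC(C)=O)[C@@H](OC(C)=O)[C@H](OC(C)=O)[C@H]2OC(C)=O)OC=C(C(=O)O)[C@H]1CC(=O)O` belongs to the same series. In this assay compound 2 also gives only a limit, > 20000 nM. Both values shown thus sit at the limit of > 20000 nM in this assay, at which 2 of the 2 values shown sit, so compound 1 stands at the limit together with every measured neighbour and no real number is known for it. Compound 3 `C/C=C1/[C@H](O[C@@H]2O[C@H](CO)[C@@H](O)[C@H](O)[C@H]2O)OC=C(C(=O)OC)[C@H]1CC(=O)OCCc1ccc(O)c(O)c1` is not yet measured; it differs from compound 1 by 2-(3,4-dihydroxyphenyl)ethoxy in place of propylamino on a carbonyl carbon. Going by the values given here, no step between measured compounds is available, so the size of this change in this assay cannot be read from the data. Compound 3 is expected to stay weak, with an expected step of an at least 1.3-fold lower number from compound 1 to compound 3 (0.12 log units; that floor lies within the scatter) that keeps it close to the limit. The estimated value of compound 3 in this assay is 15000 nM, with an expected range from 3000 nM to 60000 nM.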

Compound 3, half-maximal inhibitory concentration: 160000 nM
Compound 3: middle estimate off by 11-fold (1.03 log units), on the low side, outside the stated range (above it).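

No step from compound 1 to compound 3 can be read in this assay, because compound 1 has only a limit there: the limit of > 20000 nM in this assay, at which 2 of the 3 values shown sit.

The compounds shown leave open how 2-(3,4-dihydroxyphenyl)ethoxy and propylamino compare on that carbonyl carbon, and whether any compound of the series gives a number under that limit.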